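Compound 2 to compound 3: replacing the 3-hydroxyphenyl

This account rests on a few compounds, and the source may have more. Where it says the series, first, only, none or still open, it means among the compounds named here.

Measured so far:
compound 1 `COc1ccc(/C=C2\CCC/C(=C\c3ccc(Br)cc3)C2=O)cc1OC` - 4300 nM
compound 2 `COc1ccc(/C=C2\CCC/C(=C\c3cccc(O)c3)C2=O)cc1OC` - 1700 nM

Both values come from a functional assay on HT-1080 cells (Homo sapiens) for cytotoxicity, read by MTT assay, with a stated time of 72 h (a higher number here means a weaker inhibitor, a lower number a stronger inhibitor), and compound 2 holds the lower number of the two. Compound 3 `COc1ccc(/C=C2\CCC/C(=C\c3cccc(Cl)c3Cl)C2=O)cc1OC` comes next, with 2,3-dichlorophenyl in place of 3-hydroxyphenyl on a double-bonded chain carbon bound to a double-bonded ring carbon as its change, 2,3-dichlorophenyl in place of 3-hydroxyphenyl on a double-bonded chain carbon bound to a double-bonded ring carbon. For the measured compounds named here, the one measured step bearing on this, with 3-hydroxyphenyl in place of 4-bromophenyl, is a 2.5-fold lower number from compound 1 to compound 2 (0.40 log units; beyond the scatter) and it is modest, so a modest move back is expected for compound 3, which loses that 3-hydroxyphenyl. The expected change is a 2.1-fold higher number from compound 2 to compound 3 (0.31 log units; beyond the scatter) in this assay and it points towards a higher number. For compound 3 the estimate is 3500 nM with an expected range of 1200 nM to 10000 nM on the strength of this single step.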

Compound 3, half-maximal inhibitory concentration: 8800 nM
For compound 3 the middle estimate is 2.5-fold (0.40 log units) below the measured one, and the stated range covers the measured number.
By their numbers in this assay, from the lowest: compound 2; then compound 1; then compound 3.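

In this assay, the 2,3-dichlorophenyl group on a double-bonded chain carbon bound to a double-bonded ring carbon moves the number up both ways: a 5.2-fold higher number from compound 2 to compound 3 (0.71 log units; beyond the scatter), and a 2.0-fold higher number from compound 1 to compound 3 (0.31 log units; beyond the scatter). Among these three compounds, 3-hydroxyphenyl keeps the lowest number, with both halogen-bearing phenyl groups higher, and the dichloro group higher than 4-bromophenyl. Nothing at hand accounts for these differences.

From the compounds shown here alone, whether the hydroxyl itself matters, rather than simply the absence of halogen, remains open. So does the reading for a 3-aminophenyl or 3-carboxyphenyl group at this place.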